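The source may report more compounds than this note shows. Statements on the series, on what has been measured and on what is new or still open speak of the compounds shown alone.

In a functional assay on the whole organism (stomach) with Rattus norvegicus as the target (a lower number here means that less compound is needed, a higher number that more compound is needed for the effect), compound 3 `CN(C)/C(=N/CCCCCCn1nc(-c2ccccc2)ccc1=O)NC#N` gives 93.1 mg/kg, the highest of the two numbers in hand; its nearest, compound 1 `C/N=C(\S)NCCCCn1nc(-c2ccccc2)ccc1=O`, gives 28.9 mg/kg, a gap beyond the scatter. Compound 2 `CC/N=C(/NC#N)NCCCCCCn1nc(-c2ccccc2)ccc1=O` gives > 100 mg/kg, which is a limit of the assay and not a number. That value is the limit of > 100 mg/kg in this assay, at which 1 of the 3 values shown sits. Among the compounds with values here, the one measured step, an at least 1.0-fold lower number from compound 2 to compound 3 (0.03 log units; that floor lies within the scatter), lies within the scatter. Compound 4 `N#CNC(=N)NCCCCCn1nc(-c2ccccc2)ccc1=O` differs from compound 3 in one place: a group of 6 heavy atoms (2 carbon, 4 nitrogen; no ring) in place of a group of 9 heavy atoms (5 carbon, 4 nitrogen; no ring), on a saturated chain carbon, five bonds along the chain from an aromatic nitrogen. Within the data shown here, no measured step exchanges this group together with a shorter chain, so the expectation rests on the flat step an at least 1.0-fold lower number from compound 2 to compound 3 (0.03 log units; that floor lies within the scatter) and on the lower number of compound 1. For compound 4 an estimate of 60 mg/kg, between 20 mg/kg and 150 mg/kg, is expected. That amounts to an expected step of a 1.6-fold lower number from compound 3 to compound 4 (0.19 log units; within the scatter).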

Compound 4, dose for half-maximal effect: > 100 mg/kg
Compound 4 ended at the assay's limit; the forecaster's own chance of this, stated with the estimate: 25%; at least 1.6-fold (0.22 log units) between middle value and limit.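

In this assay compound 4 stops at a limit and not at a number, so a second compound now sits there: the limit of > 100 mg/kg in this assay, at which 2 of the 4 values shown sit. Exchanging the group of 9 heavy atoms for the group of 6 heavy atoms, five bonds along the chain from an aromatic nitrogen, gives no readable change (an at least 1.0-fold higher number from compound 3 to compound 4 (0.03 log units; that floor lies within the scatter)), and the step from compound 2 cannot be read. The gap to compound 1 is beyond the scatter (an at least 3.4-fold higher number from compound 1 to compound 4 (0.53 log units; beyond the scatter)), though its limit leaves the true size unknown. On these data alone, what a primary amine or a carboxylic acid would give at this chain end stays open, as does the true value of compound 4.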